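Dropping One Chloro Group: From Compound 1 to Compound 3

The compounds below may be only part of what the source reports. "The series", "measured", "known", "first", "only" and "open" are said of these compounds alone.

compound 1 `COc1ccc(-c2ccnc(Nc3ccc(Cl)cc3Cl)n2)cc1`: 839 nM
compound 2 `Cc1ccc(-c2ccnc(Nc3ccc(Cl)cc3Cl)n2)cc1`: > 1000 nM, a limit of the assay

Among the measured compounds shown here, in an assay on isolated protein for inhibition of phosphatidylinositol 4,5-bisphosphate 3-kinase catalytic subunit beta isoform (Homo sapiens) (a lower number here means a stronger inhibitor, a higher number a weaker inhibitor), compound 1 gives 839 nM, the only number among the two values shown. Compound 2 sits at the limit of > 1000 nM in this assay, at which 1 of the 2 values shown sits. For the measured compounds named here, the single measured step, an at least 1.1-fold higher number from compound 1 to compound 2 (0.07 log units; that floor lies within the scatter), changes a different position and says little about the change at hand. Compound 3 `COc1ccc(-c2ccnc(Nc3ccc(Cl)cc3)n2)cc1` differs from compound 1 by hydrogen in place of chloro on an aromatic carbon. Going by the values given here, with no measured step bearing on it, a modest weakening at most is expected, a 1.8-fold higher number from compound 1 to compound 3 (0.25 log units; within the scatter). Compound 3 is therefore estimated at 1500 nM, between 500 nM and 5000 nM.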

Compound 3, half-maximal inhibitory concentration: 603 nM
The estimate for compound 3 lay 2.5-fold (0.40 log units) above the measured number, and the stated range covers the measured number.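

In this assay, replacing this chloro group with hydrogen gives a 1.4-fold lower number from compound 1 to compound 3 (0.14 log units; within the scatter). The earlier compounds shown here left this position untested; now it is seen that the chloro group ortho to a large group can be lost without a change beyond the scatter. Nothing shown here accounts for this result.

Still open, from the compounds shown here alone, is whether a fluoro group, an amine or a carboxylic acid on this carbon would move the number beyond the scatter. Also open, going by these compounds, is what happens if the remaining chloro group is replaced.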